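Swapping a Hydroxyphenyl for a Methylphenyl in Rats

This account rests on a few compounds, and the source may have more. Where it says the series, first, only, none or still open, it means among the compounds named here.

compound 1 `CC1CCC(/C=N/c2ccccc2F)=C2NC=C(C(=O)O)C(=O)N21`: 14.5 umol/kg
compound 2 `CC1CCC(/C=N/c2ccccc2O)=C2NC=C(C(=O)O)C(=O)N21`: 4.11 umol/kg
compound 3 `CC1CCC(/C=N/c2ccc(O)cc2)=C2NC=C(C(=O)O)C(=O)N21`: 1.2 umol/kg

In a functional assay on the whole organism with Rattus norvegicus as the target (on this read-out higher numbers stand for an effect only at larger amounts of compound and lower numbers for an effect already at smaller amounts), compound 3 stands lowest of the three numbers: the step of a 3.4-fold lower number from compound 2 to compound 3 (0.53 log units; beyond the scatter) and the step of a 12-fold lower number from compound 1 to compound 3 (1.08 log units; beyond the scatter) both lie beyond the scatter. Compound 4 `Cc1cccc(/N=C/C2=C3NC=C(C(=O)O)C(=O)N3C(C)CC2)c1` differs from compound 3 in one place: 3-methylphenyl in place of 4-hydroxyphenyl on a double-bonded nitrogen. Within the data shown here, two measured steps bear on this. The step of a 3.5-fold lower number from compound 1 to compound 2 (0.55 log units; beyond the scatter) went with a hydroxy entering on an aromatic carbon; compound 4 goes the other way, its hydroxy leaving. The step of a 3.4-fold lower number from compound 2 to compound 3 (0.53 log units; beyond the scatter) shows that which hydroxyphenyl is present also mattered. Both point to a higher number for compound 4 in this assay, expected to be a 6.7-fold higher number from compound 3 to compound 4 (0.82 log units; beyond the scatter). Compound 4 is estimated at 8 umol/kg, within a range from 3 umol/kg to 25 umol/kg.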

Compound 4, dose for 50% inhibition: 0.8 umol/kg
Compound 4: the middle estimate sits 10-fold (1.00 log units) above what was measured; the measured number lies below the stated range.
By their numbers in this assay, from the lowest: compounds 4 and 3 (each within the scatter of the next); then compound 2; then compound 1.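

On a double-bonded nitrogen, a hydroxy is not required for a low number in this assay: 3-methylphenyl, with 0 hydrogen-bond donors and 0 hydrogen-bond acceptors, matches 4-hydroxyphenyl (a 1.5-fold lower number from compound 3 to compound 4 (0.18 log units; within the scatter)). It also stands clear of the other two groups (a 5.1-fold lower number from compound 2 to compound 4 (0.71 log units; beyond the scatter); an 18-fold lower number from compound 1 to compound 4 (1.26 log units; beyond the scatter)), so hydroxy does not track with the lower numbers across these four compounds. No measurement shown accounts for this result.

The compounds shown leave open how an amine or a methoxy group on the phenyl would compare. On these data alone, an ethyl in place of the methyl also remains open.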